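A few compounds are considered here, and "the series" means these few. Any claim that something is new, unique, unknown or untested is made for them only; others in the source may bear on it.

Compound 1 `Cn1cc(-c2nc3c(-c4ccc(CNC(=O)c5nc(C(C)(C)C)no5)c(F)c4)ccnc3[nH]2)cn1` gives 11 10^-6 cm/s in an ADME assay on Caco-2 cells (Homo sapiens) for permeability, in the apical to basolateral direction; a higher number here means that the compound crosses the layer faster, a lower number that the compound crosses the layer more slowly. Among the compounds with values here, compound 2 `CC(C)(C)c1noc(C(=O)NCc2ccc(-c3ccnc4[nH]c(-c5cnn(C6CCOCC6)c5)nc34)cc2F)n1` gives 0.8 10^-6 cm/s in this assay, and the step of a 14-fold lower number from compound 1 to compound 2 (1.14 log units; beyond the scatter) puts compound 2 at the lowest of the two numbers measured, with compound 1 as the only neighbour. Compound 3 `COc1ccnc(-c2nc3c(-c4ccc(CNC(=O)c5nc(C(C)(C)C)no5)c(F)c4)ccnc3[nH]2)c1` has not been measured; it differs from compound 2 by 4-methoxypyridin-2-yl in place of 1-(oxan-4-yl)-1H-pyrazol-4-yl on an aromatic carbon. Within the data shown here, the only measured step replaced a group on an aromatic nitrogen, not at this aromatic carbon, so it bears on the change only indirectly: it shows that the oxan-4-yl group, which leaves here together with its pyrazole ring, went with a large drop. With that group gone and a smaller aromatic group entering, an increase is expected, of a 6.3-fold higher number from compound 2 to compound 3 (0.80 log units; beyond the scatter), though a rise all the way to compound 1 is not assured. Compound 3 is therefore estimated at 5 10^-6 cm/s, in the range 1.5 10^-6 cm/s to 15 10^-6 cm/s.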

Compound 3, apparent permeability: 2.2 10^-6 cm/s
Compound 3: middle estimate off by 2.3-fold (0.36 log units), on the high side; measured number inside the range.
By their numbers in this assay, from the lowest: compound 2; then compound 3; then compound 1.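

At the aromatic carbon between two ring nitrogen atoms, replacing the whole aromatic group also changes the number in this assay, not only replacing the group on the pyrazole nitrogen. With 4-methoxypyridin-2-yl at this carbon, the two comparisons run in opposite directions: against 1-(oxan-4-yl)-1H-pyrazol-4-yl there is a 2.8-fold higher number from compound 2 to compound 3 (0.44 log units; beyond the scatter) and against 1-methyl-1H-pyrazol-4-yl there is a 5.0-fold lower number from compound 1 to compound 3 (0.70 log units; beyond the scatter), so the pyridine sits in the middle of the three and the outcome depends on which pyrazole it replaces. No measurement at hand accounts for either step.

The compounds shown do not separate the contribution of the pyridine ring from that of its methoxy group. Also open, going by these compounds, is how a pyridin-2-yl without a substituent, or one carrying a dimethylamino group, would compare with 4-methoxypyridin-2-yl at this carbon.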